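This account rests on a few compounds, and the source may have more. Where it says the series, first, only, none or still open, it means among the compounds named here.

Compound 1 `O=c1ccoc2cc(OCc3cn(Cc4ccccc4)nn3)ccc12`: in a functional assay on MDA-MB-231 cells (Homo sapiens) for cytotoxicity, read by MTT assay, with a stated time of 48 h (on this read-out lower numbers stand for stronger inhibition and higher numbers for weaker inhibition), compound 1 gives > 100000 nM, which is a limit of the assay rather than a number.
Compound 2 `O=c1ccoc2cc(OCc3cn(Cc4ccc(Cl)cc4)nn3)ccc12`: in this assay compound 2 gives > 100000 nM, again only a limit.
Compound 3 `O=c1ccoc2cc(OCc3cn(Cc4ccc(Cl)cc4Cl)nn3)ccc12`: in this assay compound 3 gives > 100000 nM, also a limit and not a measured number.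

Compound 3 therefore stands nowhere in particular on the numbers shown: its value is a limit, and it sits together with compounds 1 and 2 at the limit of > 100000 nM in this assay, at which 3 of the 3 values shown sit. The three measured steps bear on the change to compound 4 only in a weak sense. The step that the two limits leave unreadable from compound 1 to compound 2 and the step that the two limits leave unreadable from compound 2 to compound 3 are unreadable, and the same holds for a step that the two limits leave unreadable from compound 1 to compound 3, so no size can be taken from them in either direction.

Compound 4 `COc1ccc(Cn2cc(COc3ccc4c(=O)ccoc4c3)nn2)cc1` differs from compound 3 by 4-methoxyphenyl in place of 2,4-dichlorophenyl on a saturated chain carbon bound to an aromatic nitrogen. Among the measured compounds shown here, since none of the measured steps yields a readable size, no step beyond the scatter is expected from compound 3 to compound 4, and the most likely outcome is that compound 4 also returns a limit. Compound 4 is therefore expected to show the step that the limit leaves unreadable from compound 3 to compound 4 in this assay. The estimated value of compound 4 in this assay is 150000 nM, with a range from 50000 nM to 500000 nM.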

Compound 4, half-maximal inhibitory concentration: > 100000 nM
Compound 4: no number, only a limit; the forecaster's own chance of this, stated with the estimate: 85%; the middle value is on the limit's open side.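

Compound 4 adds no readable step to compound 1, compound 2 or compound 3, because each of these values is only a limit and not a number: the limit of > 100000 nM in this assay, at which 4 of the 4 values shown sit.

The compounds shown leave open how far any of them lies beyond that limit, and whether changing the benzyl group shifts the read-out at all.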